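Urea to Plain Benzamide on the Shared Core

The source may hold more compounds than are shown below. What is called first, only, known or untested is meant among the compounds shown, and "the series" means these compounds.

Measured compounds:
- compound 1, `COc1cc(-c2nn(-c3cccc(NC(=O)c4ccc(Cl)c(C(F)(F)F)c4)c3)cc2-c2ccncc2)ccc1Cl`: > 32500 nM, a limit of the assay
- compound 2, `COc1cc(-c2nn(-c3cccc(NC(=O)Nc4ccc(Cl)c(C(F)(F)F)c4)c3)cc2-c2ccncc2)ccc1Cl`: 9230 nM

In a functional assay on SN12C cells (Homo sapiens) for inhibition, read by sulforhodamine B assay, with a stated time of 48 h (on this read-out higher numbers stand for weaker inhibition of growth and lower numbers for stronger inhibition of growth), compound 2 holds the only plain number shown. Compound 1 stands at the limit of > 32500 nM in this assay, at which 1 of the 2 values shown sits. Compound 3 `COc1cc(-c2nn(-c3cccc(NC(=O)c4ccccc4)c3)cc2-c2ccncc2)ccc1Cl` differs from compound 2 by phenyl in place of (4-chloro-3-(trifluoromethyl)phenyl)amino on a carbonyl carbon. Going by the values given here, only one measured step bears on this, in reverse: an at least 3.5-fold lower number from compound 1 to compound 2 (0.54 log units; beyond the scatter). Turning the urea back into an amide is therefore expected to raise the number, while the loss of chlorine and trifluoromethyl has no measured guide. The expectation means a step of a 3.3-fold higher number from compound 2 to compound 3 (0.51 log units; beyond the scatter). Compound 3 is thus estimated at 30000 nM, between 9000 nM and 100000 nM, with a fair chance of only a limit.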

Compound 3, concentration for total growth inhibition: > 100000 nM
Compound 3: no number, only a limit; the forecaster's own chance of this, stated with the estimate: 55%; middle value at least 3.3-fold (0.52 log units) from the limit.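

In this assay, phenyl on the carbonyl carbon in place of (4-chloro-3-(trifluoromethyl)phenyl)amino gives an at least 10-fold higher number from compound 2 to compound 3 (1.03 log units; beyond the scatter), so this position does not accept the smaller group without a large loss of growth inhibition. Compound 3 gives only a limit of the assay, not a number: the limit of > 100000 nM in this assay, at which 1 of the 3 values shown sits.

From the compounds shown here alone, the step between the two compounds with limits, compound 1 and compound 3, cannot be read, so the share of chlorine and trifluoromethyl in this loss stays unknown. A urea ending in plain phenyl, or a ring carrying only chlorine or only trifluoromethyl, would separate these parts.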